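The source may report more compounds than this note shows. Statements on the series, on what has been measured and on what is new or still open speak of the compounds shown alone.

Measured in a functional assay on HepG2 cells (Homo sapiens) for cytotoxicity, read by MTT assay; a lower number here means a stronger inhibitor, a higher number a weaker inhibitor:
- compound 1 `C=CC(=O)Oc1cc(/C=C/C(=O)c2ccc(OC)c3c2OC(C)(C)C=C3)ccc1OC`: 160 nM
- compound 2 `COc1ccc(/C=C/C(=O)c2ccc(OC)c3c2OC(C)(C)C=C3)cc1OC(=O)C1CC1`: 220 nM

In this assay, within the data shown here, compound 2 gives 220 nM, which stands within the scatter of compound 1, the only other measured compound. Next is compound 3 `COc1cccc(C(=O)Oc2cc(/C=C/C(=O)c3ccc(OC)c4c3OC(C)(C)C=C4)ccc2OC)c1`, with 3-methoxyphenyl in place of cyclopropyl on a carbonyl carbon. Among the measured compounds shown here, one measured step bears on this place, a 1.4-fold higher number from compound 1 to compound 2 (0.14 log units; within the scatter), where cyclopropyl replaced vinyl and the number stayed within the scatter. For the measured compounds named here, that step offers only a weak guide, since no measured compound has an aromatic ring at this place. The expected result is a 1.1-fold higher number from compound 2 to compound 3 (0.06 log units; within the scatter), so no change beyond the scatter is anticipated in this assay. The estimate for compound 3 is 250 nM, with an expected range of 100 nM to 700 nM.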

Compound 3, half-maximal inhibitory concentration: 870 nM
The estimate for compound 3 lay 3.5-fold (0.54 log units) below the measured number; the measured number lies above the stated range.
By their numbers in this assay, from the lowest: compounds 1 and 2 (each within the scatter of the next); then compound 3.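

In this assay, the place on the carbonyl carbon proves sensitive to the group it carries, which the step of a 1.4-fold higher number from compound 1 to compound 2 (0.14 log units; within the scatter) did not show. Both routes to 3-methoxyphenyl lead to a weaker compound: a 4.0-fold higher number from compound 2 to compound 3 (0.60 log units; beyond the scatter) and a 5.4-fold higher number from compound 1 to compound 3 (0.74 log units; beyond the scatter), so an aromatic ring with a methoxy group is not tolerated here as cyclopropyl and vinyl are, at least in this one example. Nothing available explains the loss.

The compounds shown leave open whether the higher number goes with the aromatic ring itself, with the methoxy group on it, or with the move from 3 to 8 heavy atoms. A plain phenyl and a longer chain such as butyl at this place would begin to separate these readings.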